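The compounds below may be only part of what the source reports. "The series", "measured", "known", "first", "only" and "open" are said of these compounds alone.

In a functional assay on MDA-MB-231 cells (Homo sapiens) for cytotoxicity, read by MTT assay, with a stated time of 24 h (a lower number here means a stronger inhibitor, a higher number a weaker inhibitor), compound 1 (`O=C(NCc1ccccc1)OCCc1ccc(O)cc1`) gives > 100000 nM as a limit of the assay and not as a number. Compound 2 (`Cc1ccc(S(=O)(=O)NC(=O)OCCc2ccc(O)cc2)cc1`) gives > 100000 nM as a limit too. Within the data shown here, compound 1 thus stands at the limit of > 100000 nM in this assay, at which 2 of the 2 values shown sit, and no measured step exists yet to size a change. Compound 3 (`O=C(NCc1ccccc1)OCCc1ccc(OC(=O)NCc2ccccc2)cc1`) differs from compound 1 by a single change (benzylcarbamoyl in place of hydrogen on an oxygen on an aromatic ring) with benzylcarbamoyl in place of hydrogen on an oxygen on an aromatic ring. In this assay a modest move toward stronger inhibition is expected, with the estimated step of an at least 1.6-fold lower number from compound 1 to compound 3 (0.22 log units; that floor lies within the scatter) resting on the structural change alone, and a reading at the same limit remains possible. For compound 3 the estimated value is 60000 nM within an expected range from 15000 nM to 150000 nM as the likely span.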

Compound 3, half-maximal inhibitory concentration: > 100000 nM
Compound 3: only a limit was reported (the forecaster's own chance of this, stated with the estimate: 55%); at least 1.6-fold (0.22 log units) between middle value and limit.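

In this assay, compound 1 and compound 3 both give a limit and not a number, so the step from benzylcarbamoyl in place of hydrogen on an oxygen on an aromatic ring cannot be read. The compounds shown leave open how far any single change moves the number, with every reading at the same boundary: the limit of > 100000 nM in this assay, at which 3 of the 3 values shown sit.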